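This account rests on a few compounds, and the source may have more. Where it says the series, first, only, none or still open, it means among the compounds named here.

Measured so far:
compound 1, `CC(C)COc1cccc2occ(Cc3coc4ccccc4c3=O)c(=O)c12` — in a functional assay on MDA-MB-231 cells (Homo sapiens) for antiproliferative activity, read by XTT assay (a higher number here means a weaker inhibitor, a lower number a stronger inhibitor), compound 1 gives > 10000 nM, a limit of the assay.
compound 2, `O=c1c(Cc2coc3cccc(O)c3c2=O)coc2ccccc12` — in this assay compound 2 gives > 10000 nM, a limit of the assay.

Going by the values given here, compound 2 therefore stands only at a limit, not at a number, and the same holds for the one other value shown. The step that the two limits leave unreadable from compound 1 to compound 2 cannot be read, since both values sit at the limit of > 10000 nM in this assay, at which 2 of the 2 values shown sit.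

Compound 3, `O=c1c(Cc2coc3cccc(OCc4ccccc4)c3c2=O)coc2ccccc12`, is not yet measured. It differs from compound 2 by benzyl in place of hydrogen on an oxygen on an aromatic ring. Among the compounds with values here, the only measured step that bears on this change is the one from compound 1 to compound 2, which exchanges one substituent on the same oxygen for hydrogen, and its size is not readable. Within the data shown here, no measured step therefore fixes a direction or size for the new benzyl group in this assay.

Given that compound 2 already sits at the limit and that the related step gave no readable movement, compound 3 is expected to remain near that limit, with an expected step that the limit leaves unreadable from compound 2 to compound 3. The estimate for compound 3 in this assay is 15000 nM, with a range from 4000 nM to 60000 nM.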

Compound 3, half-maximal inhibitory concentration: > 10000 nM
Compound 3: no number, only a limit; the forecaster's own chance of this, stated with the estimate: 80%; the middle value is on the limit's open side.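

No new step can be read, since compound 3, like compound 1 and compound 2, stands only at a limit of the assay in this assay: the limit of > 10000 nM in this assay, at which 3 of the 3 values shown sit.

The compounds shown leave open how strong any of the three actually is, and whether any group on that oxygen changes the activity at all.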